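Cyclobutyl in place of ethyl on a ring amine nitrogen

The source may report more compounds than this note shows. Statements on the series, on what has been measured and on what is new or still open speak of the compounds shown alone.

Measured so far in an in vitro ADME assay on microsomes from liver (Homo sapiens) for pharmacokinetics (on this read-out higher numbers stand for fast clearance and lower numbers for slow clearance), are:
- compound 1 `Cc1ccc(S(=O)(=O)N2C=CNC(=O)[C@H]2CC(=O)NC2CCOCC2(C)C)cc1` with < 100 mL.min-1.g-1 as a limit
- compound 2 `CCN1CC[C@H](NC(=O)C[C@@H]2C(=O)NC=CN2S(=O)(=O)c2ccc(C)cc2)C(C)(C)C1` with < 50 mL.min-1.g-1 as a limit

In this assay compound 2 stands at < 50 mL.min-1.g-1 as a limit, not a number. Compound 1 likewise stands at < 100 mL.min-1.g-1 as a limit, not a number. Within the data shown here, the one measured step is a step that the two limits leave unreadable from compound 1 to compound 2 and it gives no size to carry forward.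

Compound 3 `Cc1ccc(S(=O)(=O)N2C=CNC(=O)[C@H]2CC(=O)N[C@H]2CCN(C3CCC3)CC2(C)C)cc1` has cyclobutyl in place of ethyl on an amine nitrogen in a ring and otherwise matches compound 2. This nitrogen lies two ring bonds from the ring atom that bears two methyl groups. Among the measured compounds shown here, no measured step covers this exchange, so the series gives it neither size nor direction.

For the measured compounds named here, the only anchor is compound 2 with < 50 mL.min-1.g-1 as its limit, and no step beyond the scatter is expected in this assay from it. The expected step is a step that the limit leaves unreadable from compound 2 to compound 3 and it carries no firm direction. For compound 3 the estimate is 35 mL.min-1.g-1 with an expected range from 12 mL.min-1.g-1 to 85 mL.min-1.g-1 and a limit of the assay is quite possible.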

Compound 3, intrinsic clearance in microsomes: 24 mL.min-1.g-1
For compound 3 the middle estimate is 1.5-fold (0.16 log units) above the measured one; the range from low to high includes it.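

No step from compound 2 to compound 3 can be read in this assay, because the result for compound 2 is a limit and not a number: the limit of < 50 mL.min-1.g-1 in this assay, at which 1 of the 3 values shown sits.

The compounds shown leave open whether cyclobutyl in place of ethyl on an amine nitrogen in a ring changes clearance in this assay, and in which direction.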